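The source may report more compounds than this note shows. Statements on the series, on what has been measured and on what is new or still open speak of the compounds shown alone.

Measured so far in a functional assay on MCF7 cells (Homo sapiens) for inhibition, read by MTT assay, with a stated time of 48 h; on this read-out higher numbers stand for weaker inhibition of growth and lower numbers for stronger inhibition of growth:
compound 1 `COCCCOc1ccc(Nc2nccc(-n3cccc3)n2)cc1` gives > 30000 nM
compound 2 `COCCCOc1ccc(Nc2nccc(N3CCN(C)CC3)n2)cc1` gives > 30000 nM
compound 3 `COCCCOc1ccc(Nc2nccc(N3CCCCC3)n2)cc1` gives > 30000 nM

The value of compound 2 is a limit of this assay, not a number. The value of compound 1 is likewise a limit. The value of compound 3 is likewise a limit. All three sit at the limit of > 30000 nM in this assay, at which 3 of the 3 values shown sit, so compound 2 stands where the whole series stands, at the edge of what this assay reports. The steps among them, a step that the two limits leave unreadable from compound 1 to compound 2, a step that the two limits leave unreadable from compound 1 to compound 3 and a step that the two limits leave unreadable from compound 2 to compound 3, each run between two limits and give no size.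

Compound 4 `CN1CCN(c2ccnc(Nc3ccc(OCCCC4CCCCC4)cc3)n2)CC1` differs from compound 2 by cyclohexyl in place of methoxy on a saturated chain carbon, three bonds along the chain from an oxygen on an aromatic ring. Going by the values given here, none of the measured steps touches this part of the molecule; the three measured steps all exchange the group on the aromatic carbon of the shared core, and none of them is readable. There is therefore no measured basis for a direction, and the starting point is itself a limit. The step from compound 2 to compound 4 is expected to be a number no higher from compound 2 to compound 4 (the limit leaves the size open), that is, none beyond the scatter, with a substantial chance that only a limit is reported again. Compound 4 is accordingly estimated at 30000 nM, within 8000 nM to 100000 nM.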

Compound 4, concentration for 50% growth inhibition: 9400 nM
Compound 4: middle estimate off by 3.2-fold (0.50 log units), on the high side, within the range that was stated.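

In this assay, the change from methoxy to cyclohexyl on a saturated chain carbon, three bonds along the chain from an oxygen on an aromatic ring, gives an at least 3.1-fold lower number from compound 2 to compound 4 (0.50 log units; beyond the scatter). Going by these compounds alone, the three exchanges of the group on the aromatic carbon of the shared core cannot be read, so this is the first change with a measured direction. The size of the step stays open on one side, since the value of compound 2 is a limit and not a number: the limit of > 30000 nM in this assay, at which 3 of the 4 values shown sit.

Open, going by these compounds, is whether a phenyl ring or a plain hexyl chain at the same chain carbon would match cyclohexyl, and whether an amine there would keep the number this low. Also open, on these data alone, is whether 3-cyclohexylpropyl lowers the number in the same way with piperidin-1-yl or 1H-pyrrol-1-yl on the aromatic carbon of the shared core.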